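Cyclopropyl in place of 1H-pyrazol-1-yl

The source may report more compounds than this note shows. Statements on the series, on what has been measured and on what is new or still open speak of the compounds shown alone.

In a functional assay on a cell-free system (plasma, Homo sapiens), with a stated time of 3 min (on this read-out lower numbers stand for stronger inhibition and higher numbers for weaker inhibition), compound 1 `CC(C)(C)[C@@H](O)C(=O)N1C[C@@H]2C[C@@H]2[C@H]1C(=O)NCc1cc(Cl)ccc1-n1cnnn1` gives 570 nM, compound 2 `O=C(NCc1cc(Cl)ccc1-n1cnnn1)[C@@H]1[C@H]2C[C@H]2CN1C(=O)[C@H](O)c1ccccc1` gives 960 nM and compound 3 `O=C(NCc1cc(Cl)ccc1-n1cnnn1)[C@@H]1[C@H]2C[C@H]2CN1C(=O)[C@H](O)Cn1cccn1` gives 1800 nM. Two steps fix the place of the last of these: a 3.2-fold higher number from compound 1 to compound 3 (0.50 log units; beyond the scatter) and a 1.9-fold higher number from compound 2 to compound 3 (0.27 log units; within the scatter). Compound 4 `O=C(NCc1cc(Cl)ccc1-n1cnnn1)[C@@H]1[C@H]2C[C@H]2CN1C(=O)[C@H](O)CC1CC1` differs from it in one place: cyclopropyl in place of 1H-pyrazol-1-yl on a saturated chain carbon, two bonds along the chain from a carbonyl carbon and an oxygen on a saturated carbon, with cyclopropyl on a saturated chain carbon, two bonds along the chain from a carbonyl carbon and an oxygen on a saturated carbon. Among the compounds with values here, no measured step makes this exact swap. The nearest guide is the modest step of a 3.2-fold higher number from compound 1 to compound 3 (0.50 log units; beyond the scatter), so a move to a lower number of similar size is expected. The expected change is a 2.3-fold lower number from compound 3 to compound 4 (0.35 log units; beyond the scatter). The estimate for compound 4 is 800 nM, within a range of 300 nM to 2000 nM.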

Compound 4, half-maximal inhibitory concentration: 1400 nM
Beside the measured number, compound 4's estimate is 1.8-fold (0.24 log units) below it; the range from low to high includes it.
By their numbers in this assay, from the lowest: compounds 1, 2, 4 and 3 (each within the scatter of the next, the first and the last beyond it).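

Replacing the aromatic 1H-pyrazol-1-yl with the non-aromatic, carbon-only cyclopropyl (a 1.3-fold lower number from compound 3 to compound 4 (0.11 log units; within the scatter)) stays within the scatter, so the pyrazole's two nitrogens and aromatic ring are not required to keep this level of inhibition. Against phenyl, cyclopropylmethyl also stays within the scatter (a 1.5-fold higher number from compound 2 to compound 4 (0.16 log units; within the scatter)), while the gap from tert-butyl remains beyond it (a 2.5-fold higher number from compound 1 to compound 4 (0.39 log units; beyond the scatter)), so compound 1 still stands apart from compound 4. No measurement here explains these differences. Going by these compounds, whether an amine, a carboxylic acid or a longer chain at this place would shift the number beyond the scatter remains open.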